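From 2,4-dimethylphenyl to 3-(trifluoromethyl)phenyl

The compounds below may be only part of what the source reports. "The series", "measured", "known", "first", "only" and "open" are said of these compounds alone.

compound 1 `CN(c1cccc2c1CN(c1nc(Nc3ccc(C(F)(F)F)cc3)ncc1C(F)(F)F)C2)S(C)(=O)=O`: > 30000 nM (a limit)
compound 2 `Cc1cc(C)cc(Nc2ncc(C(F)(F)F)c(N3Cc4cccc(N(C)S(C)(=O)=O)c4C3)n2)c1`: > 30000 nM (a limit)
compound 3 `Cc1ccc(Nc2ncc(C(F)(F)F)c(N3Cc4cccc(N(C)S(C)(=O)=O)c4C3)n2)c(C)c1`: 20700 nM

Within the data shown here, in a functional assay on A549 cells (Homo sapiens) for antiproliferative activity, read by spectrophotometry, with a stated time of 2 days (a higher number here means a weaker inhibitor of growth, a lower number a stronger inhibitor of growth), compound 3 gives 20700 nM, the only true number so far. The other two values give no number: the limit of > 30000 nM in this assay, at which 2 of the 3 values shown sit.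

Compound 4 `CN(c1cccc2c1CN(c1nc(Nc3cccc(C(F)(F)F)c3)ncc1C(F)(F)F)C2)S(C)(=O)=O` differs from compound 3 in one group: 3-(trifluoromethyl)phenyl in place of 2,4-dimethylphenyl on a nitrogen on an aromatic ring.

The most telling measured step is an at least 1.4-fold lower number from compound 1 to compound 3 (0.16 log units; that floor lies within the scatter), in which 4-(trifluoromethyl)phenyl leaves. The step of an at least 1.4-fold lower number from compound 2 to compound 3 (0.16 log units; that floor lies within the scatter) also bears on this change. Both are only floors within the scatter, so at most a small rise in the number is expected, and the result may again be only a limit.

The expected step is a 1.4-fold higher number from compound 3 to compound 4 (0.13 log units; within the scatter). For compound 4 the estimate is 28000 nM, with an expected range of 12000 nM to 50000 nM.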

Compound 4, concentration for 50% growth inhibition: > 30000 nM
Compound 4 ended at the assay's limit; the forecaster's own chance of this, stated with the estimate: 60%; middle value at least 1.0-fold (0.02 log units) from the limit.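

Compound 4 gives > 30000 nM, which is a limit of the assay and not a true number. Among these compounds, the one readable new step is an at least 1.4-fold higher number from compound 3 to compound 4 (0.16 log units; that floor lies within the scatter), so the change from 2,4-dimethylphenyl to 3-(trifluoromethyl)phenyl shows no change beyond the scatter, and the steps to compound 1 and compound 2 cannot be read. Compound 4 joins the values at the ceiling: the limit of > 30000 nM in this assay, at which 3 of the 4 values shown sit.

Going by these compounds, whether any group on this nitrogen can give a clearly lower number remains open. A phenyl ring carrying an amine or a carboxylic acid is not among the compounds shown.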